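The source may hold more compounds than are shown below. What is called first, only, known or untested is meant among the compounds shown, and "the series" means these compounds.

Compound 1 `COc1cc(C[C@H]2C(=O)OC[C@@H]2Cc2ccccc2)ccc1O` gives 93000 nM in a functional assay on HL-60 cells (Homo sapiens) for cytotoxicity, read by WST assay, with a stated time of 48 h; a higher number here means that more compound is needed for the effect, a lower number that less compound is needed.
Compound 2 `COc1ccc(C[C@H]2C(=O)OC[C@@H]2Cc2ccccc2)cc1OC` gives in this assay only a limit, > 100000 nM.
Compound 3 `COc1ccc(C[C@H]2COC(=O)[C@@H]2Cc2ccc(Cl)c(Cl)c2)cc1O` gives 32000 nM in this assay.

Compounds 1 and 2 share a core and differ in one place: methyl in place of hydrogen on an oxygen on an aromatic ring. The step is an at least 1.0-fold higher number from compound 1 to compound 2 (0.03 log units; that floor lies within the scatter). Its size is not a true number, since compound 2 sits at a limit (the limit of > 100000 nM in this assay, at which 1 of the 3 values shown sits); the step can only be read as a floor. Compound 3 carries a different core, with the chloro-bearing ring on the other side of the lactone; the difference between the core of compound 1 and the core of compound 3 is not broken down here. What the two values show is that compound 3 stands at the lower number of the two.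

Compound 4 `COc1ccc(C[C@H]2COC(=O)[C@@H]2Cc2ccc(Cl)c(Cl)c2)cc1OC` is not yet measured. It differs from compound 3 by methyl in place of hydrogen on an oxygen on an aromatic ring, which is the same change as that from compound 1 to compound 2, made on the same kind of place. The expected step is a 1.4-fold higher number from compound 3 to compound 4 (0.15 log units; within the scatter), an estimate that rests on an at least 1.0-fold higher number from compound 1 to compound 2 (0.03 log units; that floor lies within the scatter): a change of the same kind on the core of compound 1 left the number no lower, and the floor of that step lies within the scatter, so no large movement in either direction is expected. For compound 4 the value expected in this assay is 45000 nM, with a range from 20000 nM to 100000 nM, the upper end reaching the limit of the assay.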

Compound 4, half-maximal effective concentration: 24000 nM
Beside the measured number, compound 4's estimate is 1.9-fold (0.27 log units) above it, within the range that was stated.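

On the core of compound 3, methyl in place of hydrogen on an oxygen on an aromatic ring gives in this assay a 1.3-fold lower number from compound 3 to compound 4 (0.12 log units; within the scatter), so hydroxy to methoxy produces no readable change on this core. This shows that the change on this core stays within the usual scatter, but it does not show that the change has the same size on both cores: the same change on two cores in this assay, an at least 1.0-fold higher number (0.03 log units; that floor lies within the scatter) from compound 1 to compound 2 and a 1.3-fold lower number (0.12 log units; within the scatter) from compound 3 to compound 4; the limit leaves it open whether they differ. Compound 2 sits at a limit, so on the core of compound 1 the change can be read only as a floor and any upward movement there has no known size: the limit of > 100000 nM in this assay, at which 1 of the 4 values shown sits.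

The compounds shown leave open whether a group other than methyl on that oxygen, such as an ethyl group or a longer chain, or an amine in place of the hydroxy group, would move the number beyond the scatter. They also leave open how much of the gap between the values of compound 1 and compound 3 belongs to the chloro groups and how much to the other differences between the two cores, as these compounds differ in more than one place.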